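A Second Methyl on Two Cores That Show No Inhibition

The source may hold more compounds than are shown below. What is called first, only, known or untested is meant among the compounds shown, and "the series" means these compounds.

Of the compounds shown here, three have been tested in a functional assay on L1210 cells (Mus musculus) for inhibition; a higher number here means a weaker inhibitor, a lower number a stronger inhibitor. Compound 3 `CC(C)C1NC(=O)N(C2CCCCC2)C1=O` and compound 1 `CCC(C)C1NC(=O)N(C2CCCCC2)C1=O` share one core; compound 2 `CC(C)C(NC(=O)n1nnc2ccccc21)C(=O)NC1CCCC1` is built on another, and the difference between the two cores is not broken down here. In this assay compound 3 gives > 200000 nM, which is a limit of the assay and not a number. In this assay compound 1 gives > 200000 nM, again only a limit. In this assay compound 2 gives > 200000 nM, also a limit. Compound 1 differs from compound 3 by methyl in place of hydrogen on a saturated chain carbon, two bonds along the chain from a saturated ring carbon, and that change gives the step that the two limits leave unreadable from compound 3 to compound 1. Compound 4 `CCC(C)C(NC(=O)n1nnc2ccccc21)C(=O)NC1CCCC1` has not yet been measured; it differs from compound 2 by methyl in place of hydrogen on a saturated chain carbon, three bonds along the chain from an amide-type nitrogen and a carbonyl carbon, the same kind of change, though the place now lies three bonds along the chain from an amide-type nitrogen and a carbonyl carbon, not two bonds along the chain from a saturated ring carbon. Because of the limit of > 200000 nM in this assay, at which 3 of the 3 values shown sit, compound 4 is expected to stay at that limit, an estimated step that the limit leaves unreadable from compound 2 to compound 4 that shows nothing readable. The value expected for compound 4 is 300000 nM, between 100000 nM and 1000000 nM.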

Compound 4, half-maximal inhibitory concentration: 102000 nM
For compound 4 the middle estimate is 2.9-fold (0.47 log units) above the measured one; low and high end bracket the measured number.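

In this assay, replacing isopropyl with sec-butyl gives an at least 1.9-fold lower number from compound 2 to compound 4 (0.29 log units; that floor lies within the scatter), and compound 4 at 102000 nM is the only compound shown with a measured number and not a limit. That step is only a floor, set by the limit of compound 2, so the true step could be larger, but the floor itself lies within the usual scatter and does not establish that the added methyl lowers the number. The same change on the other core cannot be read, so nothing shows that it carries from one core to the other, because compound 3 and compound 1 both sit at a limit of the assay: the limit of > 200000 nM in this assay, at which 3 of the 4 values shown sit.

The compounds shown leave open whether a longer chain than sec-butyl, or an amine or a carboxylic acid at this place, would give a clearly lower number than compound 4 on its core. They also leave open whether the core shared by compound 1 and compound 3 would respond to any such group.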